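The compounds below may be only part of what the source reports. "The series", "measured", "known", "first", "only" and "open" are said of these compounds alone.

Compound 1, `Nc1nc2c(s1)CC(CNC(=O)c1ccc[nH]1)CC2`: 28000 nM
Compound 2, `Nc1nc2c(s1)CC(CNC(=O)c1cc(Br)c[nH]1)CC2`: 20000 nM
Compound 3, `Nc1nc2c(s1)C[C@@H](NC(=O)c1ccc[nH]1)CC2`: > 30000 nM (a limit of the assay, not a number)

Of the compounds shown here, three share one core and have been tested in an assay with sodium channel protein type 3 subunit alpha (Homo sapiens) as the target, read by patch clamp; a higher number here means a weaker inhibitor, a lower number a stronger inhibitor. Compound 1 gives 28000 nM in this assay, and compound 2 gives 20000 nM. These two differ in one place, and the step between them is small: a 1.4-fold lower number from compound 1 to compound 2 (0.15 log units; within the scatter). Compound 3 is different: for it the assay reports only a limit, > 30000 nM. Compound 3 thus sits at the limit of > 30000 nM in this assay, at which 1 of the 3 values shown sits, so where it stands is known only as a ceiling on potency, not as a number.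

Compound 4, `Nc1nc2c(s1)C[C@@H](NC(=O)c1cc(Br)c[nH]1)CC2`, differs from compound 3 in one place: bromo in place of hydrogen on an aromatic carbon. The same change has been measured once before, between compound 1 and compound 2, where it gave a 1.4-fold lower number from compound 1 to compound 2 (0.15 log units; within the scatter). No step beyond the scatter is therefore expected in this assay; the step expected from the limit of compound 3 is a step that the limit leaves unreadable from compound 3 to compound 4. Compound 4 is estimated at 40000 nM, with a range from 20000 nM to 90000 nM, and the assay will most likely again report only a limit.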

Compound 4, half-maximal inhibitory concentration: 26000 nM
For compound 4 the middle estimate is 1.5-fold (0.19 log units) above the measured one, within the range that was stated.
By their numbers in this assay, from the lowest: compounds 2, 4 and 1 (each within the scatter of the next). At a limit, above all of these: compound 3.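

In this assay, the change from 1H-pyrrol-2-yl to 4-bromo-1H-pyrrol-2-yl now turns a limit into a measured number on a second core, with an at least 1.1-fold lower number from compound 3 to compound 4 (0.06 log units; that floor lies within the scatter). Compound 4 therefore gives this series a number for the bromo group on this core, and it shows no rise in the number on adding the bromo group. The true size of the step on this core cannot be read, and neither can any difference between the two cores: the same change on two cores in this assay, a 1.4-fold lower number (0.15 log units; within the scatter) from compound 1 to compound 2 and an at least 1.1-fold lower number (0.06 log units; that floor lies within the scatter) from compound 3 to compound 4; the limit leaves it open whether they differ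

The compounds shown leave open whether a chlorine atom, a methyl group or a nitrile on this same aromatic carbon would shift the number beyond the scatter. They also leave open what an amine, a carboxylic acid or a longer chain would do there.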